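What Losing the Hydroxy Group Might Cost Compound 1

This account rests on a few compounds, and the source may have more. Where it says the series, first, only, none or still open, it means among the compounds named here.

In a functional assay on NCI-H460 cells (Homo sapiens) for cytotoxicity, read by sulforhodamine B assay, with a stated time of 3 days (a lower number here means a stronger inhibitor, a higher number a weaker inhibitor), compound 1 (`OCc1cn(Cc2ccc(Cl)cc2)c2ccccc12`) gives 16 nM. Compound 2 (`OCc1cn(Cc2ccc(Br)cc2)c2ccccc12`) gives 31 nM, and the two share the low end of the numbers seen so far. Compound 3 (`COc1ccc2c(c1)c(CO)cn2Cc1ccc(Cl)cc1`) stands far higher at 1510 nM.

The next compound, compound 4 (`Cc1cn(Cc2ccc(Cl)cc2)c2ccccc12`), keeps the core of compound 1 and alters a single group: hydrogen in place of hydroxy on a saturated chain carbon bound to an aromatic carbon. Put simply, hydroxymethyl becomes methyl, with hydrogen in place of hydroxy on a saturated chain carbon bound to an aromatic carbon.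

Going by the values given here, no measured step touches this place, so the evidence is only indirect. Bromo in place of chloro on an aromatic carbon gave a 1.9-fold higher number from compound 1 to compound 2 (0.29 log units; within the scatter), which says little about the hydroxy group. Methoxy in place of hydrogen on an aromatic carbon gave a 94-fold higher number from compound 1 to compound 3 (1.97 log units; beyond the scatter), so one small change can move the number far in this set. A rise beyond the scatter is therefore expected in this assay here too, though its size is uncertain. The estimated step is a 19-fold higher number from compound 1 to compound 4 (1.27 log units; beyond the scatter), towards a weaker inhibitor. Compound 4 is expected at about 300 nM, with an estimated range from 40 nM to 2500 nM.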

Compound 4, half-maximal inhibitory concentration: > 31600 nM
Compound 4 was reported as a limit; the forecaster's own chance of this, stated with the estimate: 10%; middle value at least 100-fold (2.02 log units) away from the limit.
By their numbers in this assay, from the lowest: compounds 1 and 2 (each within the scatter of the next); then compound 3. At a limit, above all of these: compound 4.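

In this assay, this is the first change shown at the saturated chain carbon bound to an aromatic carbon rather than on an aromatic carbon itself, and taking away the hydroxy group gives an at least 1900-fold higher number from compound 1 to compound 4 (3.29 log units; beyond the scatter). Compound 4 is reported only as a limit, not as an exact number: the limit of > 31600 nM in this assay, at which 1 of the 4 values shown sits. The step therefore gives a minimum size rather than a full measure, but it shows that, with the rest of compound 1 unchanged, the loss of this single oxygen atom is enough to take the number from the low end of the set to the limit.

Compound 4 alone cannot show whether the hydroxy group itself is required or whether another group at this place, such as an amine or a carboxylic acid, could take its role. It also leaves open why this change costs so much, and whether the same loss would follow with the bromo group of compound 2 or the methoxy group of compound 3 in place.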